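Swapping the Hydroxyphenyl Substituent for a Methylphenyl

The source may report more compounds than this note shows. Statements on the series, on what has been measured and on what is new or still open speak of the compounds shown alone.

Measured compounds in a functional assay on PPC-1 cells (Homo sapiens) for antiproliferative activity, read by sulforhodamine B assay; on this read-out higher numbers stand for weaker inhibition and lower numbers for stronger inhibition:
compound 1 `CCCCCCCCCCCCCCCCCCNC(=O)[C@H]1CSC(Cc2ccccc2)N1` gives 4000 nM
compound 2 `CCCCCCCCCCCCCCCCCCNC(=O)[C@H]1CSC(c2cccc(O)c2)N1` gives 1200 nM
compound 3 `CCCCCCCCCCCCCCCCCCNC(=O)[C@H]1CSC(c2cc(F)cc(F)c2)N1` gives 10600 nM

Among these three, compound 2 stands with the lowest number: the step of a 3.3-fold lower number from compound 1 to compound 2 (0.52 log units; beyond the scatter) and the step of an 8.8-fold higher number from compound 2 to compound 3 (0.95 log units; beyond the scatter) both lie beyond the scatter, so compound 2 is the strongest inhibitor of the three. Compound 4 `CCCCCCCCCCCCCCCCCCNC(=O)[C@H]1CSC(c2ccc(C)cc2)N1` has not yet been measured. It differs from compound 2 at a single position: 4-methylphenyl in place of 3-hydroxyphenyl on a saturated ring carbon.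

Within the data shown here, two measured steps bear on this change. Replacing the 3-hydroxyphenyl of compound 2 with 3,5-difluorophenyl gave an 8.8-fold higher number from compound 2 to compound 3 (0.95 log units; beyond the scatter), and replacing benzyl with 3-hydroxyphenyl gave a 3.3-fold lower number from compound 1 to compound 2 (0.52 log units; beyond the scatter); compound 2 is the only one of the three that carries a hydrogen-bond donor on this ring, and it has the lowest number. A 4-methylphenyl carries none, so a higher number than compound 2 is expected for compound 4, of roughly the size a 3.8-fold higher number from compound 2 to compound 4 (0.57 log units; beyond the scatter). Compound 4 is therefore estimated at 4500 nM, within the range 1500 nM to 13000 nM.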

Compound 4, half-maximal inhibitory concentration: 1900 nM
Beside the measured number, compound 4's estimate is 2.4-fold (0.37 log units) above it; low and high end bracket the measured number.
By their numbers in this assay, from the lowest: compounds 2 and 4 (each within the scatter of the next); then compound 1; then compound 3.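

In this assay, the step of a 1.6-fold higher number from compound 2 to compound 4 (0.20 log units; within the scatter) shows that 4-methylphenyl, which has no hydrogen-bond donor or acceptor, stands level with 3-hydroxyphenyl at this saturated ring carbon, so a donor on this ring is not required for a number in this range. Absence of a donor alone does not set the number either: the step of a 5.6-fold lower number from compound 3 to compound 4 (0.75 log units; beyond the scatter) separates two aryl groups that both lack one, and the step of a 2.1-fold lower number from compound 1 to compound 4 (0.32 log units; beyond the scatter) shows that 4-methylphenyl, like 3-hydroxyphenyl, gives a lower number than benzyl. Nothing available here explains these differences.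

The compounds shown do not separate the identity of a ring substituent from its place, which a 3-methylphenyl or a 4-hydroxyphenyl would do. They also leave open how an amine or a carboxylic acid on this phenyl ring would read.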